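The source may report more compounds than this note shows. Statements on the series, on what has been measured and on what is new or still open speak of the compounds shown alone.

Three ribosides sharing one core were compared in a functional assay on HL-60 cells (Homo sapiens) for antiproliferative activity, read by XTT assay, with a stated time of 72 h; a higher number here means a weaker inhibitor, a lower number a stronger inhibitor. Compound 2 `C#Cc1cn([C@@H]2O[C@H](CO)[C@@H](O)[C@H]2O)c2ncnc(C)c12` gives 1110 nM. Compound 1 `Cc1ncnc2c1c(I)cn2[C@@H]1O[C@H](CO)[C@@H](O)[C@H]1O` differs from it by iodo in place of ethynyl on an aromatic carbon, and in this assay compound 1 gives 2650 nM, a change that made a 2.4-fold higher number from compound 2 to compound 1 (0.38 log units; beyond the scatter). Compound 3 `C#Cc1cn([C@@H]2O[C@H](CO)[C@@H](O)[C@H]2O)c2ncnc(NC)c12` differs from compound 2 by methylamino in place of methyl on an aromatic carbon, and in this assay compound 3 gives 9060 nM, the highest of the three numbers, a change that made an 8.2-fold higher number from compound 2 to compound 3 (0.91 log units; beyond the scatter).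

Compound 4 `CNc1ncnc2c1c(I)cn2[C@@H]1O[C@H](CO)[C@@H](O)[C@H]1O` has not yet been measured in this assay. It differs from compound 3 by iodo in place of ethynyl on an aromatic carbon, the same kind of change that separates compound 1 from compound 2, and the surroundings of the exchanged group are described in identical words for both pairs; the two cores differ only in the methylamino and methyl groups already described. The step is expected to be of similar size, because on the core of compound 2 it gave a 2.4-fold higher number from compound 2 to compound 1 (0.38 log units; beyond the scatter), so the expected step is a 2.2-fold higher number from compound 3 to compound 4 (0.34 log units; beyond the scatter). Compound 4 is therefore estimated at 20000 nM, with a likely range from 7000 nM to 55000 nM.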

Compound 4, half-maximal inhibitory concentration: > 20000 nM
Compound 4 was reported as a limit; the forecaster's own chance of this, stated with the estimate: 15%; the middle value sits exactly at the limit.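

In this assay compound 4 gives > 20000 nM, which is a limit of the assay and not a number. Iodo in place of ethynyl gave an at least 2.2-fold higher number from compound 3 to compound 4 (0.34 log units; beyond the scatter), so this change raised the number on both cores, though the limit shows only a minimum for its size on the methylamino core and not whether it carried over unchanged: the same change on two cores in this assay, a 2.4-fold higher number (0.38 log units; beyond the scatter) from compound 2 to compound 1 and an at least 2.2-fold higher number (0.34 log units; beyond the scatter) from compound 3 to compound 4; the limit leaves it open whether they differ Methylamino in place of methyl gave an at least 7.5-fold higher number from compound 1 to compound 4 (0.87 log units; beyond the scatter), so this change also raised the number on both cores, again without showing whether the two steps match in size: the same change on two cores in this assay, an 8.2-fold higher number (0.91 log units; beyond the scatter) from compound 2 to compound 3 and an at least 7.5-fold higher number (0.87 log units; beyond the scatter) from compound 1 to compound 4; the limit leaves it open whether they differ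

The compounds shown leave open how other groups on this aromatic carbon, such as bromo or a nitrile, would compare with iodo and ethynyl. Going by these compounds, it is equally open whether an amino or a dimethylamino group in place of methyl would follow the course seen with methylamino.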